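Pyrrolyl enones: aryl ring substitution and growth inhibition

The source may hold more compounds than are shown below. What is called first, only, known or untested is meant among the compounds shown, and "the series" means these compounds.

Measured in a functional assay on HL-60 cells (Homo sapiens) for inhibition, read by MTT assay, with a stated time of 48 h; a lower number here means a stronger inhibitor, a higher number a weaker inhibitor:
compound 1 `O=C(/C=C/c1ccccc1)c1ccc[nH]1` — > 100000 nM
compound 2 `O=C(/C=C/c1cccc([N+](=O)[O-])c1)c1ccc[nH]1` — 20000 nM
compound 3 `O=C(/C=C/c1ccc(Cl)cc1)c1ccc[nH]1` — 13000 nM

The value of compound 1 is a limit of the assay, not a number (the limit of > 100000 nM in this assay, at which 1 of the 3 values shown sits). Compound 2 differs from compound 1 by nitro in place of hydrogen on an aromatic carbon, giving an at least 5.0-fold lower number from compound 1 to compound 2 (0.69 log units; beyond the scatter). Compound 3 differs from compound 1 by chloro in place of hydrogen on an aromatic carbon. The values of compound 2 and compound 3 lie within the scatter of each other.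

Compound 4 `O=C(/C=C/c1cc([N+](=O)[O-])ccc1Cl)c1ccc[nH]1` is not yet measured. It differs from compound 2 by chloro in place of hydrogen on an aromatic carbon. For the measured compounds named here, this is the same kind of change as the one from compound 1 to compound 3, which gave an at least 7.6-fold lower number from compound 1 to compound 3 (0.88 log units; beyond the scatter), but there the chloro enters para to a group of 9 heavy atoms, whereas in compound 4 it enters ortho to a group of 9 heavy atoms and para to a nitro group. A smaller step is expected, a 2.2-fold lower number from compound 2 to compound 4 (0.35 log units; beyond the scatter), because the step of an at least 7.6-fold lower number from compound 1 to compound 3 (0.88 log units; beyond the scatter) starts from a limit and the place of the chloro differs. Compound 4 is expected at 9000 nM, between 3000 nM and 30000 nM.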

Compound 4, half-maximal inhibitory concentration: 38000 nM
Beside the measured number, compound 4's estimate is 4.2-fold (0.63 log units) below it, outside the stated range (above it).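

In this assay, chloro in place of hydrogen on an aromatic carbon gives a 1.9-fold higher number from compound 2 to compound 4 (0.28 log units; within the scatter), so on the core of compound 2 the change brings no gain beyond the scatter. The change does not carry over in size from one core to the other: the same change on two cores in this assay, an at least 7.6-fold lower number (0.88 log units; beyond the scatter) from compound 1 to compound 3 and a 1.9-fold higher number (0.28 log units; within the scatter) from compound 2 to compound 4, at least 14-fold (1.16 log units) apart, beyond the scatter of two such steps This does not show whether the core or the place of the chloro accounts for the gap, and the earlier step rests on a limit of the assay: the limit of > 100000 nM in this assay, at which 1 of the 4 values shown sits.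

Still open, from the compounds shown here alone, is whether chloro elsewhere on the nitro-bearing ring would read differently in this assay. Also open, going by these compounds, is how an amine or a carboxylic acid would read in place of the nitro group.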